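The source may hold more compounds than are shown below. What is called first, only, known or untested is meant among the compounds shown, and "the series" means these compounds.

Measured so far:
compound 1 `CN(C)CCN(CCN(C)C)c1cccc(C(=O)N2CCc3ccc(OS(N)(=O)=O)cc3C2)c1`: 0%
compound 2 `NS(=O)(=O)Oc1ccc2c(c1)CN(C(=O)c1cccc(N3CCC(Cc4ccccc4)CC3)c1)CC2`: 1.4%
compound 3 `CCN(Cc1cccc(Br)c1)c1ccc(C(=O)N2CCc3ccc(OS(N)(=O)=O)cc3C2)cc1`: 80.2%

In an assay on HEK293 cells for inhibition of Steryl-sulfatase (Homo sapiens), tested at 0.1 uM (on this read-out higher numbers stand for a stronger effect at the one concentration tested and lower numbers for a weaker effect), compound 1 gives 0%, compound 2 gives 1.4% and compound 3 gives 80.2%. Compound 3 stands highest of the three numbers. Its nearest neighbour is compound 2, which lies far below it, beyond the scatter; compound 1 lies lowest, also beyond the scatter. Compounds 1 and 2 sit within the scatter of each other, so no order is read between them.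

Compound 4 `CCN(Cc1ccccn1)c1ccc(C(=O)N2CCc3ccc(OS(N)(=O)=O)cc3C2)cc1` has not been measured. It differs from compound 3 in one place: pyridin-2-yl in place of 3-bromophenyl on a saturated chain carbon bound to a nitrogen on an aromatic ring. For the measured compounds named here, no pair of measured compounds shows this change, so the direction of the step is not anchored by any precedent; the only fixed point is the high reading of compound 3 in this assay. The working assumption is a moderate step downward in this assay, beyond the scatter, with the compound kept well clear of the low readings.

The step expected here, a number 25.2 percentage points lower from compound 3 to compound 4 (beyond the scatter), is estimated as a decrease beyond the scatter.

For compound 4 the expected value in this assay is 55%, with an estimated range from 20% to 85%.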

Compound 4, a percentage reported as inhibition, at one concentration (the size of the read-out at that concentration, not a potency): 42.5%
Beside the measured number, compound 4's estimate is 12.5 percentage points above it; the measured number falls inside the stated range.
By their numbers in this assay, from the lowest: compounds 1 and 2 (each within the scatter of the next); then compound 4; then compound 3.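

In this assay, for the compounds shown here, the exchange of 3-bromophenyl for pyridin-2-yl on a saturated chain carbon bound to a nitrogen on an aromatic ring reads as a number 37.7 percentage points lower from compound 3 to compound 4 (beyond the scatter), the first step that isolates a change at one place. This position therefore does not tolerate every aromatic ring equally, yet the reading is not lost with this exchange: compound 4 still gives 42.5% at the one concentration tested. Nothing at hand shows what lies behind the size of this step.

The exchange removes the bromine and brings a ring nitrogen in a single move, so this one step cannot divide its size between the two, and a plain benzyl group at the same place would be the comparison that starts to separate them. Going by these compounds, how a longer chain in place of the ethyl on the same nitrogen would read in this assay also stays open, as does whether the step seen here would hold with that group changed.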